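The source may hold more compounds than are shown below. What is called first, only, known or untested is meant among the compounds shown, and "the series" means these compounds.

Working notes on the series. The variable part is the group on an amide-type nitrogen in a ring of the shared core, followed in a functional assay on SK-OV-3 cells (Homo sapiens) for antiproliferative activity, read by MTT assay, with a stated time of 72 h; a lower number here means a stronger inhibitor, a higher number a weaker inhibitor. Compound 1 `CC(=O)Oc1cccc(N2C(=O)/C(=C/N3N=C(c4ccccc4)CC3c3ccccc3O)SC2=S)c1` carries 3-acetoxyphenyl there; in this assay compound 1 gives only a limit, > 10000 nM. Compound 2 `CN1C(=O)/C(=C/N2N=C(c3ccccc3)CC2c2ccccc2O)SC1=S` carries methyl and in this assay gives 341 nM. Compound 3 `O=C1/C(=C/N2N=C(c3ccccc3)CC2c2ccccc2O)SC(=S)N1c1cccnc1` carries pyridin-3-yl; in this assay compound 3 likewise gives only a limit, > 10000 nM. Two of the three values sit at the limit of > 10000 nM in this assay, at which 2 of the 3 values shown sit, so compound 1 cannot be placed against compound 3 and that step is a step that the two limits leave unreadable from compound 1 to compound 3. The readable steps are an at least 29-fold lower number from compound 1 to compound 2 (1.46 log units; beyond the scatter) and an at least 29-fold higher number from compound 2 to compound 3 (1.46 log units; beyond the scatter): both ring-bearing groups on this nitrogen sit at the limit, while the methyl compound gives a number.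

Compound 4 `CCOC(=O)CCN1C(=O)/C(=C/N2N=C(c3ccccc3)CC2c2ccccc2O)SC1=S` is not yet measured. Relative to compound 1 the change is 2-(ethoxycarbonyl)ethyl in place of 3-acetoxyphenyl on an amide-type nitrogen in a ring. The entering group has no ring, as methyl in compound 2 has none, so the step from compound 1 to compound 2 bears most directly and a large fall is expected, though the chain is longer than methyl and a number matching compound 2 is not assumed. Compound 4 is therefore expected to give 1500 nM in this assay, within 400 nM to 8000 nM, an expected step of an at least 6.6-fold lower number from compound 1 to compound 4 (0.82 log units; beyond the scatter).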

Compound 4, half-maximal inhibitory concentration: > 10000 nM
Compound 4: a limit, no number (the forecaster's own chance of this, stated with the estimate: 25%); middle value at least 6.6-fold (0.82 log units) away from the limit.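

In this assay, among the compounds shown here, compound 4 also gives only a limit, not a number, so having no ring on this nitrogen is not enough to give a number, and compound 4 goes against the split between ring-bearing groups and methyl drawn from the earlier compounds. Placing (ethoxycarbonyl)methyl in place of hydrogen on the saturated chain carbon bound to the nitrogen gives an at least 29-fold higher number from compound 2 to compound 4 (1.46 log units; beyond the scatter). The steps to compound 4 from compound 1 and compound 3 cannot be read, and compound 2 alone keeps a number: the limit of > 10000 nM in this assay, at which 3 of the 4 values shown sit.

From the compounds shown here alone, whether this step follows from the length of the chain or from the ester remains open. An ethyl or propyl group on this nitrogen, or the same chain ending in a carboxylic acid or an amine, would separate the two.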